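This account rests on a few compounds, and the source may have more. Where it says the series, first, only, none or still open, it means among the compounds named here.

Measured in an ADME assay on L02 cells (Homo sapiens) for cytotoxicity, read by MTT assay, with a stated time of 72 h (a lower number here means a stronger inhibitor, a higher number a weaker inhibitor), as follows:
- compound 1 `C/C=C/C(=O)Nc1cccc(Oc2nc(Nc3ccn(C)n3)nc3c2CSCC3)c1` gives > 50000 nM (a limit)
- compound 2 `CCC/C=C/C(=O)Nc1cccc(Oc2nc(Nc3ccn(C)n3)nc3c2CSCC3)c1` gives > 50000 nM (a limit)
- compound 3 `C/C=C/C(=O)Nc1cccc(Oc2nc(Nc3cccc(OC)c3)nc3c2CSCC3)c1` gives > 50000 nM (a limit)

Compound 3 therefore has no number, only the limit > 50000 nM as its standing. The series as a whole shows the limit of > 50000 nM in this assay, at which 3 of the 3 values shown sit, and nothing more.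

Compound 4 `CCC/C=C/C(=O)Nc1cccc(Oc2nc(Nc3cccc(OC)c3)nc3c2CSCC3)c1` differs from compound 3 by one change: ethyl in place of hydrogen on a saturated chain carbon bound to a double-bonded chain carbon (one bond further out, methyl to propyl). The closest measured parallel is a step that the two limits leave unreadable from compound 1 to compound 2 for the same ethyl in place of hydrogen. The 3-methoxyphenyl group itself enters through a step that the two limits leave unreadable from compound 1 to compound 3 as a second related change. For the measured compounds named here, neither gives a size, so no step in a known direction can be carried over to this assay for compound 4. The parallel compound 2 stays at the limit > 50000 nM and gives no sign of a shift, so none is expected here. The expected change is a step that the limit leaves unreadable from compound 3 to compound 4 with no direction foreseen. For compound 4 the estimate is 60000 nM in an expected range from 35000 nM to 100000 nM and the most likely report is again a limit.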

Compound 4, half-maximal inhibitory concentration: > 50000 nM
Compound 4 ended at the assay's limit; the forecaster's own chance of this, stated with the estimate: 85%; the middle value is on the limit's open side.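

In this assay compound 2, compound 3 and compound 4 all stand only at a limit, so neither the step from compound 3 to compound 4 nor that from compound 2 to compound 4 can be read. The compounds shown leave open how these compounds differ in cytotoxicity, with the whole series at one limit: the limit of > 50000 nM in this assay, at which 4 of the 4 values shown sit.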